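The source may hold more compounds than are shown below. What is called first, only, known or untested is meant among the compounds shown, and "the series" means these compounds.

Compound 1 `NS(=O)(=O)Cc1ccccc1NC(=O)Nc1ccc(Cl)c(C(F)(F)F)c1` gives 460 nM in an in vitro functional assay on cells for antagonist activity at transient receptor potential cation channel subfamily V member 1 (Homo sapiens), read by reporter gene assay and calcium flux; on this read-out higher numbers stand for weaker inhibition and lower numbers for stronger inhibition. Among the compounds with values here, compound 2 `O=C(Nc1ccc(Cl)c(C(F)(F)F)c1)Nc1ccccc1CCCO` gives 220 nM and stands lowest of the two numbers; the only step so far, a 2.1-fold lower number from compound 1 to compound 2 (0.32 log units; beyond the scatter), is modest. Compound 3 `O=C(Nc1ccc(Cl)c(C(F)(F)F)c1)Nc1ccccc1CO` differs from compound 2 by hydroxy in place of 2-hydroxyethyl on a saturated chain carbon bound to an aromatic carbon — the hydroxy-bearing chain is shortened while the donor and acceptor remain. Within the data shown here, no measured step covers a chain shortening of this kind; the step from compound 1 to compound 2 swapped the group itself and bears only loosely. Compound 3 is therefore expected to lie close to compound 2, with at most a small rise, a 1.6-fold higher number from compound 2 to compound 3 (0.20 log units; within the scatter), giving an estimate of 350 nM with a range of 120 nM to 1000 nM.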

Compound 3, half-maximal inhibitory concentration: 330 nM
Beside the measured number, compound 3's estimate is 1.1-fold (0.03 log units) above it; low and high end bracket the measured number.
By their numbers in this assay, from the lowest: compounds 2, 3 and 1 (each within the scatter of the next, the first and the last beyond it).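

At this place, on a saturated chain carbon bound to an aromatic carbon, this assay reads a 1.5-fold higher number from compound 2 to compound 3 (0.18 log units; within the scatter) for hydroxy in place of 2-hydroxyethyl, so 3-hydroxypropyl and hydroxymethyl are not told apart here. Hydroxy in place of sulfamoyl reads a 1.4-fold lower number from compound 1 to compound 3 (0.14 log units; within the scatter) and is not told apart either, so compound 3 lies within the scatter of both compound 1 and compound 2, though those two lie beyond it from each other. Nothing on hand bears on the reason for these numbers.

As far as these compounds go, whether this flat reading holds for an amine or a carboxylic acid at the same place stays open. So does the reading for a chain longer than 3-hydroxypropyl.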